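Swapping methoxy for fluoro on the benzyl ring

A few compounds are considered here, and "the series" means these few. Any claim that something is new, unique, unknown or untested is made for them only; others in the source may bear on it.

Compound 1 `CNC(=O)c1cc(C(=O)NC2CCC2)cn(Cc2ccncc2)c1=O` — 1.7
Compound 2 `CNC(=O)c1cc(C(=O)NCCC2CCOCC2)cn(Cc2ccccc2)c1=O` — 3.6
Compound 3 `CNC(=O)c1cc(C(=O)NC2CC2)cn(Cc2ccc(OC)cc2)c1=O` — 3

Of the compounds shown here, three sharing one core have been measured in a physicochemical assay for lipophilicity, at pH 7.4; a lower number here means a more polar compound, a higher number a more lipophilic compound. Compound 3 stands second highest of the three: compound 2 gives 3.6, a higher number and beyond the usual scatter, while compound 1 gives 1.7, a lower number and also beyond the scatter.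

Compound 4 `CNC(=O)c1cc(C(=O)NC2CC2)cn(Cc2ccc(F)cc2)c1=O` is not yet measured. It differs from compound 3 in one place: fluoro in place of methoxy on an aromatic carbon. The methoxy leaves and fluoro enters, on an aromatic carbon of a six-membered aromatic ring of carbon only, para to a large group.

Among the compounds with values here, no pair of measured compounds shows this exact change, so its size has to be judged from the change itself. A small rise in this assay is expected, at most around the edge of the scatter. The expected step of a number 0.20 log units higher from compound 3 to compound 4 (within the scatter) is therefore small and upward. Compound 4 is estimated to give 3.2, with a likely range from 2.8 to 3.6.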

Compound 4, distribution coefficient: 3.2
Compound 4: middle estimate and measured number agree at the digits printed; low and high end bracket the measured number.
By their numbers in this assay, from the lowest: compound 1; then compounds 3 and 4 (each within the scatter of the next); then compound 2.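

In this assay, fluoro in place of methoxy on an aromatic carbon, para to a large group, gives a number 0.20 log units higher from compound 3 to compound 4 (within the scatter), so the two compounds cannot be told apart in this measurement. Within the data shown here, this is the first pair here that differs in one place, and it gives a direct reading at this position: exchanging methoxy, with its two heavy atoms and one hydrogen-bond acceptor, for fluoro, with one heavy atom and no acceptor, leaves the number within the scatter. No measurement shown here explains why these two groups read so alike.

As far as these compounds go, what an amine or a carboxylic acid on this same aromatic carbon would do in this assay remains open. So does whether the change from 4-methoxyphenyl to 4-fluorophenyl would give a similar step with a different group on the amide of the shared core.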